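A few compounds are considered here, and "the series" means these few. Any claim that something is new, unique, unknown or untested is made for them only; others in the source may bear on it.

Compound 1 `CC(c1cccc(NS(C)(=O)=O)c1)c1c[nH]cn1`: 692 nM
Compound 2 `CS(=O)(=O)Nc1cccc2c1CCCC2C1=NCCN1`: 4270 nM
Compound 3 `Cn1cnc(C2CCCc3c(NS(C)(=O)=O)cccc32)c1`: 1050 nM

In an assay on isolated protein for binding affinity to Alpha-1D adrenergic receptor (Rattus norvegicus), read by radioligand binding (on this read-out higher numbers stand for weaker inhibition and lower numbers for stronger inhibition), compound 3 gives 1050 nM, the second highest of the three numbers. Compound 1 gives 692 nM, within the scatter of compound 3. Among the measured compounds shown here, compound 2 gives 4270 nM, and the single one-place step seen so far is a 4.1-fold lower number from compound 2 to compound 3 (0.61 log units; beyond the scatter). Compound 4 `Cn1cncc1C1CCCc2c(NS(C)(=O)=O)cccc21` differs from compound 3 in that (1-methyl-1H-imidazol-5-yl in place of 1-methyl-1H-imidazol-4-yl on a saturated ring carbon). For the measured compounds named here, that earlier step replaced one kind of ring with another; here the same atoms are merely joined differently, so no measured step speaks directly to this change. The expectation is therefore a step of a 1.4-fold higher number from compound 3 to compound 4 (0.15 log units; within the scatter), likely no larger than the scatter. Compound 4 is estimated at 1500 nM, with a range from 500 nM to 5000 nM.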

Compound 4, inhibition constant: < 10000 nM
Compound 4: only a limit was reported; the forecaster's own chance of this, stated with the estimate: 5%; the middle value does not contradict the limit.
By their numbers in this assay, from the lowest: compounds 1 and 3 (each within the scatter of the next); then compound 2.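

In this assay compound 4 gives < 10000 nM, which is a limit and not a number, so its steps from compound 2 and compound 3 cannot be read. The compounds shown leave open whether 1-methyl-1H-imidazol-5-yl in place of 1-methyl-1H-imidazol-4-yl changes the binding affinity at all.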